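Methyl-to-hydrogen step carried across two enaminone cores

This account rests on a few compounds, and the source may have more. Where it says the series, first, only, none or still open, it means among the compounds named here.

Compound 1 `COc1cc(OC)c2sc(-c3ccc(N/C=C\C(=O)c4ccc(OC)c([N+](=O)[O-])c4)c(C)c3)nc2c1` and compound 2 `COc1cc(OC)c2sc(-c3ccc(N/C=C\C(=O)c4ccc(OC)c([N+](=O)[O-])c4)cc3)nc2c1` share one core. In a functional assay on HeLa cells (Homo sapiens) for antiproliferative activity, read by sulforhodamine B assay, with a stated time of 48 h (on this read-out higher numbers stand for weaker inhibition and lower numbers for stronger inhibition), compound 1 gives 9390 nM, and compound 2 gives 12900 nM. The change between them is hydrogen in place of methyl on an aromatic carbon, and the step it made is a 1.4-fold higher number from compound 1 to compound 2 (0.14 log units; within the scatter).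

Compound 3 `COc1cc(C(=O)/C=C\Nc2ccc(-c3nc4cc(OC)c(OC)c(OC)c4s3)cc2C)cc(OC)c1OC` carries a second core. How this core differs from the core of compound 1 is not broken down here. In this assay compound 3 gives 11100 nM, a number that sits close to those of compound 1 and compound 2 and within the scatter of both.

Compound 4 `COc1cc(C(=O)/C=C\Nc2ccc(-c3nc4cc(OC)c(OC)c(OC)c4s3)cc2)cc(OC)c1OC` is not yet measured. It differs from compound 3 by hydrogen in place of methyl on an aromatic carbon. Among the measured compounds shown here, this is the same change as the one from compound 1 to compound 2: what leaves, what enters and the place are described in the same words in both cases, so the one measured step is the only guide to the size of the expected one.

For compound 4 the expected step in this assay is a 1.3-fold higher number from compound 3 to compound 4 (0.12 log units; within the scatter), resting on the measured step of a 1.4-fold higher number from compound 1 to compound 2 (0.14 log units; within the scatter) and on the value of compound 3, 11100 nM. Because that measured step lies within the scatter, the estimate for compound 4 in this assay is 14500 nM, with a range from 7000 nM to 30000 nM, and the number is expected to stay near that of compound 3 rather than to move clearly in either direction.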

Compound 4, half-maximal inhibitory concentration: 5300 nM
Compound 4: middle estimate off by 2.7-fold (0.44 log units), on the high side; the measured number lies below the stated range.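

On the core of compound 3, hydrogen in place of methyl on an aromatic carbon gives a 2.1-fold lower number from compound 3 to compound 4 (0.32 log units; beyond the scatter) in this assay, a modest step beyond the scatter, whereas the same change on the core of compound 1 stays within it. The same change described in the same words therefore does not carry a fixed size from one core to the other in this series, and the step on one core is a poor guide to the step on the other: the same change on two cores in this assay, a 1.4-fold higher number (0.14 log units; within the scatter) from compound 1 to compound 2 and a 2.1-fold lower number (0.32 log units; beyond the scatter) from compound 3 to compound 4, 2.9-fold (0.46 log units) apart, beyond the scatter of two such steps

This rests on only two matched pairs and shows a dependence on the core, not its cause, since the two cores differ in more than one place and no compound shown separates those differences.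

From the compounds shown here alone, it remains open which part of the core governs the size of the step, and whether a core bearing the methoxy and nitro pattern on one side with the other side of the second core would behave like compound 1 or like compound 3. Also open, going by these compounds, is how a larger replacement at the same place, such as an ethyl group, a chlorine atom or an amine, would behave on each of the two cores.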